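This account rests on a few compounds, and the source may have more. Where it says the series, first, only, none or still open, it means among the compounds named here.

In a functional assay on HCT-116 cells (Homo sapiens) for cytotoxicity, read by scintillation counting and thymidine incorporation, with a stated time of 72 h (a higher number here means a weaker inhibitor, a lower number a stronger inhibitor), three compounds sharing one core have been measured, and they differ in the group on a double-bonded chain carbon bound to a double-bonded chain carbon. Compound 3 `CC=C(c1cc(OC)cc(OC)c1)c1ccc(OC)c(OC)c1`, which carries methyl there, gives 480 nM. Compound 1 `COc1cc(OC)cc(C(=CC#N)c2ccc(OC)c(OC)c2)c1`, which carries cyano, gives 18 nM, so compound 3 has the higher of the two actual numbers. Compound 2 `COc1cc(OC)cc(C(=CCCN(C)C)c2ccc(OC)c(OC)c2)c1`, which carries 2-(dimethylamino)ethyl, reaches only a limit of the assay, > 10000 nM.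

The next compound is compound 4 `COc1cc(OC)cc(C(=CC(C)=O)c2ccc(OC)c(OC)c2)c1`, in which acetyl takes the place of the methyl of compound 3: acetyl in place of methyl on a double-bonded chain carbon bound to a double-bonded chain carbon. Acetyl has not been measured on this core, so the evidence is indirect. Two measured steps at this same place bear on it, and both are large: a 27-fold higher number from compound 1 to compound 3 (1.43 log units; beyond the scatter), and an at least 20-fold lower number from compound 2 to compound 3 (1.31 log units; beyond the scatter). Changes here can therefore move the number a long way in either direction. Acetyl resembles cyano more than it resembles the 2-(dimethylamino)ethyl chain, so a shift towards compound 1 seems likelier than one towards compound 2, though probably not the whole way. The expected change is a 4.8-fold lower number from compound 3 to compound 4 (0.68 log units; beyond the scatter). For compound 4 the estimated value is 100 nM, with an expected range from 25 nM to 500 nM.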

Compound 4, half-maximal inhibitory concentration: > 10000 nM
Compound 4 ended at the assay's limit; the forecaster's own chance of this, stated with the estimate: 3%; middle value at least 100-fold (2.00 log units) from the limit.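

In this assay, acetyl does not act as a stand-in for cyano at this place on the shared core, giving an at least 550-fold higher number from compound 1 to compound 4 (2.74 log units; beyond the scatter). It also does worse than methyl, with an at least 20-fold higher number from compound 3 to compound 4 (1.31 log units; beyond the scatter), so a group that differs from cyano and methyl can lose nearly all measurable activity here, and the loss is not confined to the long 2-(dimethylamino)ethyl chain of compound 2. Two quite different groups, one holding an amine and the other a carbonyl, now end at the same limit of the assay, and the step between compound 2 and compound 4 cannot be read because both rest on that limit: the limit of > 10000 nM in this assay, at which 2 of the 4 values shown sit.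

So far, only cyano and methyl give actual numbers at this place, and compound 2 and compound 4 cannot be put in order. On these data alone, it remains open whether the low number of compound 1 is particular to cyano, or whether a primary amide, a carboxylic acid, a methyl ester or plain hydrogen on the same carbon would also give a readable number.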